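The source may report more compounds than this note shows. Statements on the series, on what has been measured and on what is new or still open speak of the compounds shown alone.

Compound 1 `CCN(CC)CCCNc1nc(-c2ccc(NC(=O)Nc3ccccc3)cc2)nc2c(Cl)c(Cl)sc12`: 1640 nM
Compound 2 `CCN(CC)CCCNc1nc(-c2ccc(NC(=O)Nc3ccc(Cl)cc3Cl)cc2)nc2c(Cl)c(Cl)sc12`: 5720 nM

In a functional assay on MKN-45 cells (Homo sapiens) for cytotoxicity, read by MTT assay, with a stated time of 72 h (a lower number here means a stronger inhibitor, a higher number a weaker inhibitor), compound 2 holds the higher of the two numbers; the step of a 3.5-fold higher number from compound 1 to compound 2 (0.54 log units; beyond the scatter) lies beyond the scatter. Compound 3 `CCN(CC)CCCNc1nc(-c2ccc(NC(=O)Nc3ccc(C)cc3)cc2)nc2c(Cl)c(Cl)sc12` differs from compound 2 by 4-methylphenyl in place of 2,4-dichlorophenyl on an amide-type nitrogen. Going by the values given here, no measured step covers this exact exchange; the only one touching this amide-type nitrogen, a 3.5-fold higher number from compound 1 to compound 2 (0.54 log units; beyond the scatter), shows that the group there moves the number. Removing the dichloro pattern is expected to bring compound 3 back toward compound 1, so a lower number is expected, namely a 2.9-fold lower number from compound 2 to compound 3 (0.46 log units; beyond the scatter). Compound 3 is estimated at 2000 nM, within 700 nM to 6000 nM.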

Compound 3, half-maximal inhibitory concentration: 3320 nM
Compound 3: the middle estimate sits 1.7-fold (0.22 log units) below what was measured; the range from low to high includes it.
By their numbers in this assay, from the lowest: compound 1; then compounds 3 and 2 (each within the scatter of the next).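

Exchanging 2,4-dichlorophenyl for 4-methylphenyl on the amide-type nitrogen gives no readable difference in this assay (a 1.7-fold lower number from compound 2 to compound 3 (0.24 log units; within the scatter)). Yet a single methyl in place of hydrogen on an aromatic carbon is enough for a modest rise (a 2.0-fold higher number from compound 1 to compound 3 (0.31 log units; beyond the scatter)), so the number can sit above that of the plain phenyl without any chlorine on the ring. No available measurement explains this result. Going by these compounds, whether other groups on this phenyl, such as an amine, a methoxy group or a carboxylic acid, also raise the number stays open. These three compounds also cannot separate which group is present from where it sits on the ring.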